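The source may hold more compounds than are shown below. What is called first, only, known or untested is meant among the compounds shown, and "the series" means these compounds.

Measured in a functional assay on HEK293 cells for agonist activity at Bombesin receptor subtype-3 (Homo sapiens), read by luminescence and calcium flux, with a stated time of 10 min; a higher number here means that more compound is needed for the effect, a lower number that less compound is needed:
compound 1 `CCC(C)(C)Cc1c[nH]c(CCc2ccc(-c3ccncc3)cc2)n1` — 95 nM
compound 2 `CCC(C)(C)Cc1c[nH]c(CCc2ccc(-c3cnccn3)cc2)n1` — 100 nM
compound 3 `CCC(C)(C)Cc1c[nH]c(CCc2ccc(N3CCCCC3)cc2)n1` — 108 nM

Compound 3 holds the highest of the three numbers, but this means little: a 1.1-fold higher number from compound 1 to compound 3 (0.06 log units; within the scatter) and a 1.1-fold higher number from compound 2 to compound 3 (0.03 log units; within the scatter) both fall inside the scatter, as does a 1.1-fold higher number from compound 1 to compound 2 (0.02 log units; within the scatter). All three measured steps exchange the group on the same aromatic carbon, and none moved the read-out.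

Compound 4 `CCC(C)(C)Cc1c[nH]c(CCc2ccc(-n3cccn3)cc2)n1` is the next exchange at that carbon: 1H-pyrazol-1-yl in place of piperidin-1-yl on an aromatic carbon. The three earlier swaps are the relevant precedent, and none left the scatter, so no step beyond the scatter is expected here either; the estimated step is a 1.0-fold lower number from compound 3 to compound 4 (0.01 log units; within the scatter), because a 1.1-fold higher number from compound 1 to compound 3 (0.06 log units; within the scatter) and a 1.1-fold higher number from compound 2 to compound 3 (0.03 log units; within the scatter) stayed flat. Compound 4 is expected at 105 nM, with a range from 50 nM to 220 nM.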

Compound 4, half-maximal effective concentration: 106 nM
The estimate for compound 4 lay 1.0-fold (0.00 log units) below the measured number; low and high end bracket the measured number.
By their numbers in this assay, from the lowest: compounds 1, 2, 4 and 3 (each within the scatter of the next).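

In this assay, 1H-pyrazol-1-yl adds a five-membered aromatic ring with 2 hetero atoms to the groups on this aromatic carbon, and the read-out stays flat against piperidin-1-yl (a 1.0-fold lower number from compound 3 to compound 4 (0.01 log units; within the scatter)), pyrazin-2-yl (a 1.1-fold higher number from compound 2 to compound 4 (0.03 log units; within the scatter)) and pyridin-4-yl (a 1.1-fold higher number from compound 1 to compound 4 (0.05 log units; within the scatter)). At this position, five-membered and six-membered rings, aromatic or not, therefore show no step beyond the scatter. No measurement accounts for this flatness.

Going by these compounds, whether an open alkyl chain, an amine or a carboxylic acid on this carbon would also stay within the scatter remains open.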